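The compounds below may be only part of what the source reports. "The series", "measured", "known", "first", "only" and "open" are said of these compounds alone.

In an ADME assay on microsomes from liver (Homo sapiens) for metabolic stability, read by LC-MS, using NADPH, with stated times of 5 min and 30 min, tested at 1 uM (a lower number here means slower removal, a higher number faster removal of the compound), compound 1 (`Fc1ccc2c(c1CNc1ncc(Oc3ccccc3)c3nncn13)CCO2`) gives 18 mL.min-1.g-1 as its number. Compound 2 (`CN(C)C(=O)c1cc(-c2cnc(NCc3c(F)ccc4c3CCO4)c3cn[nH]c(=O)c23)n(C)n1`) at 21 mL.min-1.g-1 lies within the scatter of it, while compound 3 (`Cc1ncccc1-c1cnc(NCc2c(F)ccc3c2CCO3)c2cn[nH]c(=O)c12`) at 41 mL.min-1.g-1 lies beyond the scatter above it. Compound 4 (`CN(C(=O)c1ccccc1)c1cnc(NCc2c(F)ccc3c2CCO3)n2cnnc12`) keeps the core of compound 1 but carries benzoyl(methyl)amino in place of phenoxy on an aromatic carbon. Among the compounds with values here, the only measured step (a 2.0-fold higher number from compound 2 to compound 3 (0.29 log units; within the scatter)) swaps other groups on another core and bears only loosely on this change. No shift beyond the scatter is therefore expected in this assay and the data give no firm direction. The expected change is small (a 1.4-fold higher number from compound 1 to compound 4 (0.14 log units; within the scatter)). For compound 4 the estimated value is 25 mL.min-1.g-1 (range 11 mL.min-1.g-1 to 55 mL.min-1.g-1).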

Compound 4, intrinsic clearance in microsomes: > 300 mL.min-1.g-1
Compound 4: no number, only a limit; the forecaster's own chance of this, stated with the estimate: 5%; middle value at least 12-fold (1.07 log units) from the limit.
By their numbers in this assay, from the lowest: compounds 1, 2 and 3 (each within the scatter of the next, the first and the last beyond it). At a limit, above all of these: compound 4.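

In this assay, benzoyl(methyl)amino in place of phenoxy on the core of compound 1 gives an at least 16-fold higher number from compound 1 to compound 4 (1.22 log units; beyond the scatter). Compound 4 has no number here, only a limit: the limit of > 300 mL.min-1.g-1 in this assay, at which 1 of the 4 values shown sits. Compounds 1, 2 and 3 did not show that a single change at this position, on an aromatic carbon of the core, could produce a step of this size.

The compounds shown leave open how far compound 4 lies past its limit, and which part of the entering group goes with the step. Going by these compounds, it also remains open whether a plain amine or the benzamide without its methyl would stay close to compound 1.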